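The source may report more compounds than this note shows. Statements on the series, on what has been measured and on what is new or still open speak of the compounds shown alone.

In a functional assay on COLO 205 cells (Homo sapiens) for inhibition, read by MTT assay, with a stated time of 48 h (a higher number here means a weaker inhibitor, a lower number a stronger inhibitor), compound 1 (`COc1cc(C(=O)/C=C/c2ccc(O)cc2)cc(OC)c1OC`) gives 29700 nM while compound 2 (`COc1cc(C(=O)/C=C/c2ccc(C)cc2)cc(OC)c1OC`) gives 41500 nM and so stands within the scatter of compound 1. Compound 3 (`COc1cc(C(=O)/C=C/c2cccc(C=O)c2)cc(OC)c1OC`), not yet measured, differs from compound 2 as 3-formylphenyl in place of 4-methylphenyl on a double-bonded chain carbon bound to a double-bonded chain carbon shows, with 3-formylphenyl in place of 4-methylphenyl on a double-bonded chain carbon bound to a double-bonded chain carbon. Within the data shown here, only one measured step bears on this, and only loosely: methyl in place of hydroxy on an aromatic carbon gave a 1.4-fold higher number from compound 1 to compound 2 (0.15 log units; within the scatter) and no more. Among the measured compounds shown here, no measured compound carries a formyl group, so the data offer no direction. No change beyond the scatter is therefore expected in this assay for this swap. The estimate thus means a 1.4-fold lower number from compound 2 to compound 3 (0.14 log units; within the scatter) as the expected change. For compound 3 the estimated value is 30000 nM with the range 10000 nM to 85000 nM expected to hold most repeat measurements.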

Compound 3, half-maximal inhibitory concentration: 22500 nM
The estimate for compound 3 lay 1.3-fold (0.12 log units) above the measured number; measured number inside the range.
By their numbers in this assay, from the lowest: compounds 3, 1 and 2 (each within the scatter of the next).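

In this assay, replacing the whole substituted phenyl group on the double-bonded chain carbon left the number within the scatter: 3-formylphenyl in place of 4-methylphenyl gave a 1.8-fold lower number from compound 2 to compound 3 (0.27 log units; within the scatter), and 3-formylphenyl in place of 4-hydroxyphenyl gave a 1.3-fold lower number from compound 1 to compound 3 (0.12 log units; within the scatter). The earlier pair had shown only an exchange of one group for another in the 4-substituted phenyl series, whereas compound 3 shows that a formyl group in the 3-substituted form also stays within the scatter of both earlier compounds. Nothing available explains this result.

The compounds shown leave open whether an amine or a carboxylic acid on this phenyl ring would move the number beyond the scatter. They also leave open whether 4-formylphenyl would match 3-formylphenyl on the shared core.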